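The compounds below may be only part of what the source reports. "The series", "measured", "known", "first", "only" and "open" are said of these compounds alone.

For the measured compounds named here, in an ADME assay on microsomes from liver (Mus musculus) for metabolic stability, read by LC-MS, with a stated time of 10 min, tested at 0.5 uM (a lower number here means that less of the compound is left, a higher number that more of the compound is left), compound 1 `CC(C)N1CCN(CCCN(C[C@H]2Cc3ccccc3CN2)[C@H]2CCCc3cccnc32)CC1` gives 58% and stands lowest of the two numbers so far, with compound 2 `c1cnc(CN(CCCN2CCNCC2)[C@H]2CCCc3cccnc32)nc1` at 78% and the gap beyond the scatter. Compound 3 `CN1CCN(CCCN(C[C@H]2Cc3ccccc3CN2)[C@H]2CCCc3cccnc32)CC1` differs from compound 1 by methyl in place of isopropyl on an amine nitrogen in a ring with methyl in place of isopropyl on an amine nitrogen in a ring. Going by the values given here, no measured step covers this change, so no step beyond the scatter is expected in this assay for it. The estimated a number 2 percentage points higher from compound 1 to compound 3 (within the scatter) is expected to stay within the scatter. For compound 3 the expected value is 60% with an estimated range from 44% to 76% for the measurement.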

Compound 3, percent of the compound remaining: 53%
Compound 3: middle estimate off by 7 percentage points, on the high side, within the range that was stated.
By their numbers in this assay, from the lowest: compounds 3 and 1 (each within the scatter of the next); then compound 2.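

In this assay, for the compounds shown here, the step of a number 5 percentage points lower from compound 1 to compound 3 (within the scatter) gives the first reading at this position, on an amine nitrogen in a ring. For this pair, the size of the group on that nitrogen, isopropyl or methyl, leaves the percent remaining without a change beyond the scatter. No measurement on hand speaks to the reason for this result. Open, going by these compounds, is whether an acetyl group or a hydroxyethyl group on this nitrogen would shift the percent remaining. Also open, on these data alone, is whether the same swap reads alike on the core of compound 2.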